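The source may hold more compounds than are shown below. What is called first, only, known or untested is meant among the compounds shown, and "the series" means these compounds.

Three compounds share one core, each carrying a single halogen on the aromatic ring: compound 1 `C[C@@H](NC(=O)Nc1cccc(F)c1)c1ccccc1`, compound 2 `C[C@@H](NC(=O)Nc1cccc(Cl)c1)c1ccccc1` and compound 3 `C[C@@H](NC(=O)Nc1cccc(I)c1)c1ccccc1`. In an ADME assay on the whole organism with Oryza sativa as the target, tested at 1 uM (on this read-out higher numbers stand for a weaker effect at the one concentration tested and lower numbers for a stronger effect), compound 1 gives 95%, compound 2 gives 91% and compound 3 gives 75%. Compound 2 thus stands second highest of the three numbers, close to compound 1 and well apart from compound 3.

Compound 4 `C[C@@H](NC(=O)Nc1cc(Cl)cc(Cl)c1)c1ccccc1` differs from compound 2 by chloro in place of hydrogen on an aromatic carbon. For the measured compounds named here, no measured step adds a second halogen, so the bearing of the earlier steps is indirect. Swapping one halogen for another gave a number 4 percentage points lower from compound 1 to compound 2 (within the scatter), a number 16 percentage points lower from compound 2 to compound 3 (beyond the scatter) and a number 20 percentage points lower from compound 1 to compound 3 (beyond the scatter); a larger halogen went with a lower number, while fluoro against chloro changed little. A second chloro is therefore expected to lower the number at most modestly, if at all. The step from compound 2 to compound 4 is estimated at a number 7 percentage points lower from compound 2 to compound 4 (within the scatter). Compound 4 is expected to give 84%, between 68% and 98%.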

Compound 4, a percentage reported as activity, at one concentration (the size of the read-out at that concentration, not a potency): 99%
For compound 4 the middle estimate is 15 percentage points below the measured one; measured number outside the range, above it.
By their numbers in this assay, from the lowest: compound 3; then compounds 2, 1 and 4 (each within the scatter of the next).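

For the compounds shown here, compound 4 is the first case here in which a new group fills an aromatic carbon that held hydrogen, rather than one halogen replacing another. This second chloro, meta to a chloro group, gives a number 8 percentage points higher from compound 2 to compound 4 (within the scatter) in this assay, so adding it at this position leaves the read-out within the usual scatter, whereas replacing the chloro of compound 2 with iodo gave a number 16 percentage points lower from compound 2 to compound 3 (beyond the scatter). Nothing measured here explains why these two changes differ.

Going by these compounds, it remains open whether an iodo group on this same carbon would lower the number, as the swap to iodo did in compound 3. On these data alone, it is also open whether a non-halogen group here, such as a methoxy group or an amine, would be tolerated in the same way as chloro.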